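Dihydropyridine diesters bearing a chloroimidazole: ester chain variation

The compounds below may be only part of what the source reports. "The series", "measured", "known", "first", "only" and "open" are said of these compounds alone.

Measured so far:
compound 1, `CCOC(=O)C1=C(C)NC(C)=C(C(=O)OCC)C1c1[nH]cnc1Cl`, 437 nM
compound 2, `CCCOC(=O)C1=C(C)NC(C)=C(C(=O)OCCC)C1c1[nH]cnc1Cl`, 63.1 nM
compound 3, `CCCOC(=O)C1=C(C)NC(C)=C(C(=O)OC)C1c1[nH]cnc1Cl`, 437 nM

In an assay on isolated protein for inhibition of Voltage-dependent L-type calcium channel subunit alpha-1C (Cavia porcellus) (a higher number here means a weaker inhibitor, a lower number a stronger inhibitor), compound 3 gives 437 nM, level with compound 1 at the digits shown; the two together stand at the highest number of the three, and compound 2 lies furthest from them at 63.1 nM.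

For the measured compounds named here, the one step that touches the ester chain directly is the loss of two chain carbons from compound 2 to compound 3: a 6.9-fold higher number from compound 2 to compound 3 (0.84 log units; beyond the scatter). Compound 1 and compound 2 show the same direction without a single-point step: the diethyl diester gives a higher number than the dipropyl diester.

Compound 4, `COC(=O)C1=C(C)NC(C)=C(C(=O)OCCc2ccccc2)C1c1[nH]cnc1Cl`, differs from compound 3 by phenyl in place of methyl on a saturated chain carbon, two bonds along the chain from an oxygen next to a carbonyl group. The change runs the opposite way from the step between compound 2 and compound 3, extending the chain by a ring rather than trimming it. Going by the values given here, the only relevant evidence points toward a lower number with a longer ester chain, so a step of roughly the same size, in the stronger direction, is expected in this assay: a 5.5-fold lower number from compound 3 to compound 4 (0.74 log units; beyond the scatter). As far as these compounds go, whether a phenyl goes beyond what a propyl achieves is unknown from these three compounds, so the range is kept wide. Compound 4 is estimated at 80 nM, with a range from 25 nM to 300 nM.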

Compound 4, half-maximal inhibitory concentration: 79.4 nM
Estimate against measurement, compound 4: 1.0-fold (0.00 log units) above, within the range that was stated.
By their numbers in this assay, from the lowest: compounds 2 and 4 (each within the scatter of the next); then compounds 1 and 3 (each within the scatter of the next).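

In this assay the ester chain that stayed propyl through the earlier step also responds to change: with the methyl ester held fixed, propyl to phenethyl gives a 5.5-fold lower number from compound 3 to compound 4 (0.74 log units; beyond the scatter) and so adds a second ester position with a step beyond the scatter. For the compounds shown here, the chain end therefore accepts a six-membered aromatic ring of carbon only, the first group that is not a plain alkyl chain, and the number moves down with it rather than up. Nothing measured here accounts for the change.

Compound 4 brings a ring and a longer chain in a single step, so the contribution of each stays unresolved; a plain butyl or pentyl ester at this place, with the methyl ester kept, would separate the two. Also open, as far as these compounds go, are how the number responds to a benzyl or 3-phenylpropyl ester, which alter the distance to the ring, to a pyridine ring in place of the phenyl, and to phenethyl paired with a propyl ester rather than the methyl ester.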